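This account rests on a few compounds, and the source may have more. Where it says the series, first, only, none or still open, it means among the compounds named here.

Series so far, read in a physicochemical assay for solubility, read by chemiluminescence, measured as kinetic solubility; on this read-out higher numbers stand for higher solubility and lower numbers for lower solubility:

Compound 1 `O=C(C1CCCCC1)N1CCC2(CCN(c3nccc(NCc4ccc(Cl)cc4Cl)n3)CC2)C1`: 3 ug/mL
Compound 2 `O=C(c1ccccn1)N1CCC2(CCN(c3nccc(NCc4ccc(Cl)cc4Cl)n3)CC2)C1`: 17 ug/mL

Compound 2, at 17 ug/mL, holds the highest of the two numbers. Next in line is compound 3 `Clc1ccc(CNc2ccnc(N3CCC4(CCN(C[C@@H]5CCCN5)C4)CC3)n2)c(Cl)c1`, which differs from it as follows: (pyrrolidin-2-yl)methyl in place of (pyridin-2-yl)carbonyl on an amine nitrogen in a ring. In words, (pyrrolidin-2-yl)methyl stands in place of (pyridin-2-yl)carbonyl on an amine nitrogen in a ring.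

For the measured compounds named here, only one measured step bears on this change, and only loosely: a 5.7-fold higher number from compound 1 to compound 2 (0.75 log units; beyond the scatter). Going by the values given here, that step exchanged the group on a carbonyl carbon, whereas here the carbonyl itself leaves, so no measured step covers this change directly. Among the compounds with values here, with that single modest step as the only guide to size, a rise of comparable size in this assay is expected, with wide uncertainty. The expected step is a 4.1-fold higher number from compound 2 to compound 3 (0.61 log units; beyond the scatter). For compound 3 the estimated value is 70 ug/mL, with an expected range of 20 ug/mL to 250 ug/mL.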

Compound 3, solubility: 56 ug/mL
Beside the measured number, compound 3's estimate is 1.3-fold (0.10 log units) above it; low and high end bracket the measured number.
By their numbers in this assay, from the lowest: compound 1; then compound 2; then compound 3.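

In this assay, the amine nitrogen of the five-membered ring need not carry a carbonyl for the number to stay high: (pyrrolidin-2-yl)methyl in place of (pyridin-2-yl)carbonyl gives a 3.3-fold higher number from compound 2 to compound 3 (0.52 log units; beyond the scatter), so the rise seen among the carbonyl-linked groups continues once the carbonyl and the aromatic ring are gone. Against cyclohexylcarbonyl, the same group gives a 19-fold higher number from compound 1 to compound 3 (1.27 log units; beyond the scatter), the only step in the series that ranks as large. No measurement here accounts for either step.

As far as these compounds go, the change alters several things at once, so the share of the carbonyl, the ring and the new hydrogen-bond donor stays open. A (pyridin-2-yl)methyl or a (pyrrolidin-2-yl)carbonyl group on the same nitrogen would separate them, and the other stereoisomer of the (pyrrolidin-2-yl)methyl group would test the defined stereocentre.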